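Hydrazone aryl swap on the isatin-derived thiosemicarbazone series

A few compounds are considered here, and "the series" means these few. Any claim that something is new, unique, unknown or untested is made for them only; others in the source may bear on it.

Measured so far:
- compound 1, `Cc1ccc(O)c(/C=N/NC(=S)N/N=C2\C(=O)Nc3ccc(C)cc32)c1`: > 50000 nM
- compound 2, `Cc1ccc2c(c1)/C(=N/NC(=S)N/N=C/c1c(Cl)cccc1Cl)C(=O)N2`: 1790 nM

Two compounds share the core and differ only in the aryl group on the carbon with a double bond to nitrogen. In a functional assay on HeLa cells (Homo sapiens) for inhibition, read by MTT assay (a lower number here means a stronger inhibitor, a higher number a weaker inhibitor), compound 1 gives only a limit, > 50000 nM, and no number. In this assay compound 2 gives 1790 nM, the only number shown in the set. Among the compounds with values here, the step of an at least 27-fold lower number from compound 1 to compound 2 (1.44 log units; beyond the scatter) is the only measured step, and it sits at the same place as the change now considered; its size is bounded from one side by the limit of > 50000 nM in this assay, at which 1 of the 2 values shown sits.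

Compound 3, `Cc1ccc2c(c1)/C(=N/NC(=S)N/N=C/c1ccccn1)C(=O)N2`, is not yet measured. It differs from compound 2 by pyridin-2-yl in place of 2,6-dichlorophenyl on a carbon with a double bond to nitrogen. Within the data shown here, the single measured step shows that this position moves the read-out strongly, but it compares a substituted phenyl against a dichlorophenyl, not against a pyridin-2-yl, so the direction for compound 3 is not fixed by the data. Compound 3 is expected to give 6000 nM, between 1500 nM and 30000 nM, a step of a 3.4-fold higher number from compound 2 to compound 3 (0.53 log units; beyond the scatter) from compound 2, with a real chance of a limit only.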

Compound 3, half-maximal inhibitory concentration: 3150 nM
Compound 3: middle estimate off by 1.9-fold (0.28 log units), on the high side; measured number inside the range.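

In this assay, pyridin-2-yl in place of 2,6-dichlorophenyl gives a 1.8-fold higher number from compound 2 to compound 3 (0.25 log units; within the scatter), so these two groups cannot be told apart on the carbon with a double bond to nitrogen. Set against 2-hydroxy-5-methylphenyl, pyridin-2-yl gives an at least 15-fold lower number from compound 1 to compound 3 (1.20 log units; beyond the scatter), so the large step at this place also appears with a group that holds no chlorine, and among the three compounds only the 2-hydroxy-5-methylphenyl group stands apart. The size of that step is open on one side, as compound 1 gives only a limit and no number: the limit of > 50000 nM in this assay, at which 1 of the 3 values shown sits.

The compounds shown leave open whether the hydroxy group, the methyl group or both of them in 2-hydroxy-5-methylphenyl go with the weak read-out of compound 1, a question that a plain phenyl or a 2-hydroxyphenyl group at this place would address. Also open, as far as these compounds go, is how far this place tolerates other groups, such as a dimethylamino-substituted phenyl or a benzoic acid, and whether the flat result for 2,6-dichlorophenyl and pyridin-2-yl holds with any change to the shared core.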